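Adding a methoxy group to a benzothiazole amide

A few compounds are considered here, and "the series" means these few. Any claim that something is new, unique, unknown or untested is made for them only; others in the source may bear on it.

Three compounds were measured in a functional assay on HCT-116 cells (Homo sapiens) for inhibition, read by colorimetric assay, with a stated time of 3 days; on this read-out lower numbers stand for stronger inhibition and higher numbers for weaker inhibition:
Compound 1, `COc1ccc(OC)c(NC(=O)CCCCCCNC(=O)C(O)(O)C(F)(F)F)c1`, gives 3870 nM.
Compound 2, `COc1cccc(NC(=O)CCCCCCNC(=O)C(O)(O)C(F)(F)F)c1`, gives 6110 nM.
Compound 3, `O=C(CCCCCCNC(=O)C(O)(O)C(F)(F)F)Nc1nc2ccccc2s1`, gives 2370 nM.

Compounds 1 and 2 share one core and differ by methoxy in place of hydrogen on an aromatic carbon; this gives a 1.6-fold lower number from compound 2 to compound 1 (0.20 log units; within the scatter). Compounds 2 and 3 differ in their cores by 1,3-benzothiazol-2-yl in place of 3-methoxyphenyl on an amide-type nitrogen, with a 2.6-fold lower number from compound 2 to compound 3 (0.41 log units; beyond the scatter). Compound 3 has the lowest of the three numbers, but its gap to compound 1 is within the scatter, so only its separation from compound 2 counts as a real difference.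

Compound 4, `COc1ccc2nc(NC(=O)CCCCCCNC(=O)C(O)(O)C(F)(F)F)sc2c1`, has not yet been measured. It differs from compound 3 by methoxy in place of hydrogen on an aromatic carbon. Among the compounds with values here, this is the same kind of change as the one from compound 2 to compound 1, though not the same: there the place was on an aromatic carbon of a six-membered aromatic ring of carbon only, ortho to a large group and para to a methoxy group, whereas here it is part of a fused or bridged system of two rings, meta to a fused ring and para to a fused ring.

The expectation for compound 4 in this assay rests on the earlier step being small, because a 1.6-fold lower number from compound 2 to compound 1 (0.20 log units; within the scatter) lies within the scatter. Compound 4 is therefore estimated to give 1800 nM, a step of a 1.3-fold lower number from compound 3 to compound 4 (0.12 log units; within the scatter), with a range from 700 nM to 4500 nM.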

Compound 4, half-maximal inhibitory concentration: 7560 nM
For compound 4 the middle estimate is 4.2-fold (0.62 log units) below the measured one; measured number above the stated range.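

In this assay, methoxy in place of hydrogen on an aromatic carbon gives a 3.2-fold higher number from compound 3 to compound 4 (0.50 log units; beyond the scatter), so on the core of compound 3 this change weakens inhibition by a margin that counts as real. Set beside the step on the other core, which lies within the scatter, the change does not carry over with the same result, and the two steps differ by more than repeated measurement would explain: the same change on two cores in this assay, a 1.6-fold lower number (0.20 log units; within the scatter) from compound 2 to compound 1 and a 3.2-fold higher number (0.50 log units; beyond the scatter) from compound 3 to compound 4, 5.0-fold (0.70 log units) apart, beyond the scatter of two such steps. Within the data shown here, this does not show what sets the two cores apart, since the methoxy group occupies a different kind of place on each and there is only one pair per core, so the effect of the core cannot be separated from the effect of the place, and no rule for other cores follows.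

The compounds shown leave open whether a methoxy group at another aromatic carbon of the core of compound 3 would give a similar step, and whether a fluorine atom or a hydroxy group at the same place would behave as methoxy does. They also leave open whether the difference between the cores would persist with a shorter or a longer chain between the two amide groups.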